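Pyridin-3-yl in Place of the Methylpyrazole on a Shared Core

The source may hold more compounds than are shown below. What is called first, only, known or untested is meant among the compounds shown, and "the series" means these compounds.

Compound 1, `c1ccc(-c2cccc3c2CCC3c2ncc[nH]2)nc1`: in a functional assay on CHO cells for agonist activity at Alpha-1A adrenergic receptor (Homo sapiens), read by FLIPR and calcium flux (on this read-out lower numbers stand for smaller maximal responses and higher numbers for larger maximal responses), compound 1 gives 53%.
Compound 2, `c1cc(-c2ccn[nH]2)c2c(c1)C(c1ncc[nH]1)CC2`: compound 2 gives 83%.
Compound 3, `Cn1nccc1-c1cccc2c1CCC2c1ncc[nH]1`: compound 3 gives 58%.

Compound 3 stands second highest of the three: its nearest neighbour is compound 1, a number 5 percentage points higher from compound 1 to compound 3 (within the scatter), while compound 2 lies furthest away, a number 25 percentage points lower from compound 2 to compound 3 (beyond the scatter). Compound 4, `c1cncc(-c2cccc3c2CCC3c2ncc[nH]2)c1`, differs from compound 3 in one place: pyridin-3-yl in place of 1-methyl-1H-pyrazol-5-yl on an aromatic carbon. Among the measured compounds shown here, two measured steps bear on this. The exchange of pyridin-2-yl for 1-methyl-1H-pyrazol-5-yl moved the number only within the scatter, a number 5 percentage points higher from compound 1 to compound 3 (within the scatter), whereas the modest rise appeared only with 1H-pyrazol-5-yl, a number 30 percentage points higher from compound 1 to compound 2 (beyond the scatter), a group compound 4 does not carry. A six-membered ring with one nitrogen in this place is thus expected to leave the maximal response about where compound 3 has it, a number 3 percentage points lower from compound 3 to compound 4 (within the scatter), within the scatter. Compound 4 is estimated at 55%, in the range 35% to 75%.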

Compound 4, largest response reached (Emax), in percent of the reference or control that the assay uses: 36%
Beside the measured number, compound 4's estimate is 19 percentage points above it; the range from low to high includes it.
By their numbers in this assay, from the lowest: compound 4; then compounds 1 and 3 (each within the scatter of the next); then compound 2.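

In this assay, this position responds to where the nitrogen sits in the six-membered ring alone: pyridin-3-yl in place of pyridin-2-yl gives a drop beyond the scatter (a number 17 percentage points lower from compound 1 to compound 4 (beyond the scatter)). Pyridin-3-yl also falls below both five-membered groups, modestly against 1-methyl-1H-pyrazol-5-yl (a number 22 percentage points lower from compound 3 to compound 4 (beyond the scatter)) and by a large step against 1H-pyrazol-5-yl (a number 47 percentage points lower from compound 2 to compound 4 (beyond the scatter)). Compound 4 thus stands apart from all three earlier compounds. On these data alone, whether pyridin-4-yl or an amine on this aromatic carbon would raise or lower the maximal response remains open. No measurement shown here accounts for these steps.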